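The source may hold more compounds than are shown below. What is called first, only, known or untested is meant among the compounds shown, and "the series" means these compounds.

Going by the values given here, compound 1, with the structure `C=CCn1c(=O)/c(=C\c2cccc(C)c2)[nH]c(=O)/c1=C\c1ccccc1OC`, is the one compound in this set to give a number in a functional assay on Huh-7 cells (Homo sapiens) for cytotoxicity, read by CCK-8 assay, with a stated time of 72 h (a lower number here means a stronger inhibitor, a higher number a weaker inhibitor), where compound 1 gives 21400 nM. The two other measured compounds give no number: compound 2, with the structure `COc1ccccc1/C=c1/[nH]c(=O)/c(=C\c2ccccc2OC)[nH]c1=O`, is recorded in this assay as "not active" (no number reported), and compound 3, with the structure `C=CCn1c(=O)/c(=C\c2ccc(Cl)c(Cl)c2)[nH]c(=O)/c1=C\c1ccccc1`, is likewise recorded in this assay as "not active" (no number reported). Among the compounds with values here, no two of the measured compounds differ in one place only, so no single step within the measured set can be drawn on.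

Compound 4, with the structure `C=CCn1c(=O)/c(=C\c2cc(F)ccc2C)[nH]c(=O)/c1=C\c1ccccc1OC`, differs from compound 1 as follows: 5-fluoro-2-methylphenyl in place of 3-methylphenyl on a double-bonded chain carbon bound to an aromatic carbon. Within the data shown here, with no comparable step among the measured compounds to guide the expectation, the change is expected to move the value by no more than the usual scatter, in no clear direction, so that the expected step of a 1.0-fold higher number from compound 1 to compound 4 (0.01 log units; within the scatter) is small. Compound 4 is therefore estimated at 22000 nM in this assay, with a range from 8000 nM to 60000 nM.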

Compound 4, half-maximal inhibitory concentration: 5600 nM
Compound 4: middle estimate off by 3.9-fold (0.59 log units), on the high side; the whole stated range lies above it.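

The aryl group on a double-bonded chain carbon bound to an aromatic carbon proves to be a place where the number in this assay can move: 5-fluoro-2-methylphenyl in place of 3-methylphenyl gives a step beyond the scatter (a 3.8-fold lower number from compound 1 to compound 4 (0.58 log units; beyond the scatter)). Going by these compounds alone, until this pair, the set offered no single-place step, so it could not show whether a change at this position would register at all. Nothing available explains why this change lowers the number.

The step combines an added fluorine with a different placing of the methyl, and the compounds shown do not separate the two. Also open, going by these compounds, is how the number would respond to 2-methylphenyl alone, 3-fluorophenyl, or a phenyl ring carrying an amine or a carboxylic acid at this position.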